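Cyclohexyl for 3-methoxyphenyl, starting from a limit

A few compounds are considered here, and "the series" means these few. Any claim that something is new, unique, unknown or untested is made for them only; others in the source may bear on it.

Of the compounds shown here, two have been measured so far in a functional assay on HeLa cells (Homo sapiens) for antiproliferative activity, read by MTT assay, with a stated time of 72 h (a higher number here means a weaker inhibitor, a lower number a stronger inhibitor), and neither gives a number. Compound 1 (`O=C1COc2ccc(-c3cnc(Cl)c(NS(=O)(=O)c4ccc(F)cc4)c3)cc2N1c1ccc(F)cc1`) reads > 40000 nM, which is a limit of the assay. Compound 2 (`COc1cccc(N2C(=O)COc3ccc(-c4cccc(NS(=O)(=O)c5ccc(F)cc5)c4)cc32)c1`) reads > 40000 nM, which is again a limit. For the measured compounds named here, the whole record so far is the limit of > 40000 nM in this assay, at which 2 of the 2 values shown sit, so compound 2 has no exact position and no measured compound can be ranked against it.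

Compound 3 (`O=C1COc2ccc(-c3cccc(NS(=O)(=O)c4ccc(F)cc4)c3)cc2N1C1CCCCC1`) has cyclohexyl in place of 3-methoxyphenyl on an amide-type nitrogen in a ring, three ring bonds from the ring oxygen: cyclohexyl in place of 3-methoxyphenyl on an amide-type nitrogen in a ring. Going by the values given here, no measured pair differs in a single place, so the data offer no direct guide to the size of this change. Little or no step beyond the scatter is expected in this assay, with any shift more likely toward stronger inhibition, since compound 2 can only stay level or improve on the scale. The estimated step is small: an at least 1.1-fold lower number from compound 2 to compound 3 (0.05 log units; that floor lies within the scatter). For compound 3 the expected value is 35000 nM, within an estimated range of 10000 nM to 80000 nM.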

Compound 3, half-maximal inhibitory concentration: 10800 nM
For compound 3 the middle estimate is 3.2-fold (0.51 log units) above the measured one, and the stated range covers the measured number.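

In this assay, compound 3 is the only one of the three compounds shown to give an exact value, so this amide-type nitrogen in a ring, three ring bonds from the ring oxygen, is a place where changing the group moves the read-out beyond the scatter: an at least 3.7-fold lower number from compound 2 to compound 3 (0.56 log units; beyond the scatter). Compound 2 gives > 40000 nM, which is a limit of the assay and not a number. The true size of the step therefore remains unknown and only its lower bound can be read, because the starting compound sits at that limit: the limit of > 40000 nM in this assay, at which 2 of the 3 values shown sit.

The change removes the aromatic ring and the methoxy oxygen together, so the compounds shown cannot separate the two, and they leave open how plain phenyl or a smaller carbon ring such as cyclopentyl on the same nitrogen would read. They also leave open whether an amine or a carboxylic acid carried on the cyclohexyl ring would keep, strengthen or lose the inhibition seen with compound 3.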